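The source may hold more compounds than are shown below. What is called first, only, known or untested is meant among the compounds shown, and "the series" means these compounds.

Working notes on the series.

Four compounds share one core. For the measured compounds named here, in an ADME assay on microsomes from liver (Rattus norvegicus), read by LC-MS, using NADPH, with a stated time of 30 min, tested at 1 uM (on this read-out higher numbers stand for a more stable compound and lower numbers for a less stable compound), compound 1 `C[C@H](Nc1ccnc(N)n1)c1cc2ccc(F)cn2c(=O)c1-c1ccccc1` gives "not determined" (no result reported), and in this assay compound 2 `Cc1c([C@H](C)Nc2ncnc(N)c2C#N)c(-c2ccc(F)cc2)c2ccc(F)cn2c1=O` likewise gives "not determined" (no result reported); for neither of them is a number on hand, so they give no footing for the step considered here. Going by the values given here, compound 3 `C[C@H](Nc1nc(N)nc(N)c1C#N)c1c(-c2ccccc2)c(=O)n2cc(F)ccc2c1C1CC1` is the only member of the set with a reading in this assay: compound 3 gives 84%, which places it as the sole reference point, with nothing to rank it against.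

The step to be followed leads to compound 4 `COc1ccc(-c2c([C@H](C)Nc3nc(N)nc(N)c3C#N)c(-c3ccccc3)c(=O)n3cc(F)ccc23)cc1`, which has not yet been measured in this assay. The structural change from compound 3 to compound 4 is 4-methoxyphenyl in place of cyclopropyl on an aromatic carbon. Among the compounds with values here, no pair of measured compounds in this set differs in a single place, so there is no measured step on which to lean, and the size of the change can only be expected, not inferred from a precedent.

Given the single reading of compound 3 and the absence of any comparable step, the expectation for compound 4 is a modest drop, expressed as a number 19 percentage points lower from compound 3 to compound 4 (beyond the scatter), with wide uncertainty around it. Compound 4 is therefore estimated at 65%, the range running from 35% to 90%, to be checked against the measurement.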

Compound 4, percent of the compound remaining: 76%
Estimate against measurement, compound 4: 11 percentage points below; low and high end bracket the measured number.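

In this assay the exchange of cyclopropyl for 4-methoxyphenyl gives a number 8 percentage points lower from compound 3 to compound 4 (within the scatter), so the two readings cannot be told apart, although the group at this position grows from a three-membered non-aromatic ring to a six-membered aromatic ring bearing a hydrogen-bond acceptor. For the compounds shown here, this is the first measured step in the set, and it shows that this aromatic carbon, ortho to a fused ring and ortho to a large group, accepts either group on the shared core without a separable difference in this read-out, something compound 1 and compound 2 could not show without numbers. Nothing measured on hand accounts for this result, and no explanation of it can be offered.

Going by these compounds, only cyclopropyl and 4-methoxyphenyl have readings at this position, so whether the same holds for an amine, a carboxylic acid or a longer alkyl chain remains open. Also open, on these data alone, is whether the methoxy group itself matters, as a plain phenyl at this position would separate the contribution of the aromatic ring from that of the oxygen-bearing substituent.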